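Aryl urea series: methoxy to fluoro on the aniline ring

The compounds below may be only part of what the source reports. "The series", "measured", "known", "first", "only" and "open" are said of these compounds alone.

Measured so far:
- compound 1, `CCc1ccccc1NC(=O)N[C@@H](C)c1ccccc1`; in an ADME assay on the whole organism with Oryza sativa as the target, tested at 0.1 uM (a higher number here means a weaker effect of the compound at the concentration tested, a lower number a stronger effect), compound 1 gives 100%
- compound 2, `COc1ccccc1NC(=O)N[C@@H](C)c1ccccc1`; in this assay compound 2 gives 98%

Compound 2 holds the lower of the two numbers in this assay, but the gap to compound 1 is small: the step of a number 2 percentage points lower from compound 1 to compound 2 (within the scatter) stays within the scatter, so the two compounds cannot be ordered on this read-out.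

Compound 3, `C[C@H](NC(=O)Nc1ccccc1F)c1ccccc1`, is still to be measured. It differs from compound 2 by fluoro in place of methoxy on an aromatic carbon.

Within the data shown here, only one measured step bears on this change, the exchange of the group on the same aromatic carbon between compound 1 and compound 2, and it was a number 2 percentage points lower from compound 1 to compound 2 (within the scatter), within the scatter. Both measured numbers sit near the top of the scale, so no step beyond the scatter is expected from compound 2 to compound 3 in this assay: a number 1 percentage points lower from compound 2 to compound 3 (within the scatter).

Compound 3 is therefore expected to give 97% in this assay, within a range from 88% to 100%.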

Compound 3, a percentage reported as activity, at one concentration (the size of the read-out at that concentration, not a potency): 98%
Beside the measured number, compound 3's estimate is 1 percentage points below it; the range from low to high includes it.
By their numbers in this assay, from the lowest: compounds 2, 3 and 1 (each within the scatter of the next).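

In this assay, the aromatic carbon ortho to a large group now carries a third group, and the exchange for fluoro gives no change at the digits printed from compound 2 to compound 3 (within the scatter), while the comparison with ethyl gives a number 2 percentage points lower from compound 1 to compound 3 (within the scatter). Ethyl, methoxy and fluoro therefore cannot be told apart at this place on this read-out, even though fluoro has fewer heavy atoms than methoxy and, unlike methoxy, counts no hydrogen-bond acceptor. Nothing available accounts for this flat reading.

Going by these compounds, all three numbers sit near the top of the scale, so it remains open whether any group at this carbon can shift the read-out beyond the scatter. On these data alone, an amine, a carboxylic acid or a longer chain on the same aromatic carbon would test this, and the effect of changes elsewhere on the shared core is also open.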